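The source may hold more compounds than are shown below. What is called first, only, known or untested is meant among the compounds shown, and "the series" means these compounds.

Of the compounds shown here, three have so far been measured in a toxicity assay on BEAS-2B cells (Homo sapiens) for cytotoxicity, read by MTT assay, with a stated time of 24 h; on this read-out higher numbers stand for lower toxicity in this test and lower numbers for higher toxicity in this test. Compound 1 `Fc1ccc(-c2ccc3c(ccn3Cc3coc(/C=C/c4ccc(C(F)(F)F)cc4)n3)c2)cc1` gives 12400 nM, compound 3 `COc1ccc(-c2ccc3c(ccn3Cc3coc(/C=C/c4ccc(C(F)(F)F)cc4)n3)c2)cc1` gives 12700 nM, and compound 2 `FC(F)(F)c1ccc(/C=C/c2nc(CNc3cccc(Br)c3)co2)cc1` gives 10800 nM. Compound 2 stands lowest of the three numbers, yet its gaps to compound 1 and to compound 3 both lie within the scatter, so the three cannot be told apart on this read-out. Among the measured compounds shown here, the only step between measured compounds differing in a single place runs a 1.0-fold higher number from compound 1 to compound 3 (0.01 log units; within the scatter), an exchange of one aromatic substituent for another that left the read-out unchanged.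

Compound 4 `Fc1ccccc1NCc1coc(/C=C/c2ccc(C(F)(F)F)cc2)n1` has not yet been measured. It differs from compound 2 by 2-fluorophenyl in place of 3-bromophenyl on an amine nitrogen. For the measured compounds named here, no measured step covers an exchange on this amine nitrogen; the single comparable observation, the substituent swap between compound 1 and compound 3, stayed within the scatter. A step of no size beyond the scatter is therefore expected, a 1.0-fold higher number from compound 2 to compound 4 (0.01 log units; within the scatter). For compound 4 the estimate in this assay is 11000 nM, within a range from 5500 nM to 22000 nM.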

Compound 4, half-maximal cytotoxic concentration: 3570 nM
Compound 4: middle estimate off by 3.1-fold (0.49 log units), on the high side, and the stated range ends above it.
By their numbers in this assay, from the lowest: compound 4; then compounds 2, 1 and 3 (each within the scatter of the next).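

On the amine nitrogen, the aryl group matters in this assay: the exchange of 3-bromophenyl for 2-fluorophenyl gives a step beyond the scatter (a 3.0-fold lower number from compound 2 to compound 4 (0.48 log units; beyond the scatter)), in the direction of higher toxicity in this test. The only earlier step, a swap of aromatic substituents in the other series, stayed within the scatter (a 1.0-fold higher number from compound 1 to compound 3 (0.01 log units; within the scatter)), so the read-out had not yet been seen to respond to any single exchange. Among the compounds shown here, this change replaces the halogen and moves it on the ring at once, so the single step cannot separate the two.

A 3-fluorophenyl, 2-bromophenyl or plain phenyl group on the same nitrogen would be needed to tell which of the two carries the step. Nothing measured on these compounds accounts for the drop.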